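A few compounds are considered here, and "the series" means these few. Any claim that something is new, unique, unknown or untested is made for them only; others in the source may bear on it.

Series notes. Compound 1 `Cc1ccc(C(=O)N[C@H]2CCN(Cc3ccc(OCCCN(C)C)cc3)C2)cc1C` and compound 2 `CN(C)CCCOc1ccc(CN2CC[C@H](NC(=O)c3ccc(C(F)(F)F)cc3)C2)cc1` carry different aryl groups on the carbonyl carbon of the shared core. In an assay on HEK293 cells for binding affinity to Urotensin-2 receptor (Homo sapiens), read by radioligand binding (on this read-out higher numbers stand for weaker inhibition and lower numbers for stronger inhibition), compound 1 gives only a limit, < 10000 nM. In this assay compound 2 likewise gives only a limit, < 10000 nM. Among the measured compounds shown here, compound 3 `CN(C)CCCOc1ccc(CN2CC[C@H](NC(=O)c3ccccc3)C2)cc1` gives the one actual number in this assay, 2510 nM. The steps a step that the two limits leave unreadable from compound 1 to compound 2, a step that the limit leaves unreadable from compound 1 to compound 3 and a step that the limit leaves unreadable from compound 2 to compound 3 are all unreadable because two of the three values sit at the limit of < 10000 nM in this assay, at which 2 of the 3 values shown sit. Compound 3 thus stands as the sole numerical anchor of the series, with no ordering against compound 1 or compound 2 that the numbers support.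

Compound 4 `CN(C)CCCOc1ccc(CN2CC[C@H](NC(=O)c3ccc4ccccc4c3)C2)cc1` is not yet measured. It differs from compound 3 by naphthalen-2-yl in place of phenyl on a carbonyl carbon. For the measured compounds named here, none of the measured steps bears directly on this change; each of them swaps the aryl group on the carbonyl carbon for a substituted phenyl, and none can be read in size. The expectation therefore rests only on the value of compound 3 in this assay, 2510 nM, and carries a wide range. For compound 4 the expected inhibition constant in this assay is 1000 nM, between 200 nM and 6000 nM. The step of a 2.5-fold lower number from compound 3 to compound 4 (0.40 log units; beyond the scatter) is the estimated outcome, with no direction firmly supported by the data.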

Compound 4, inhibition constant: < 10000 nM
Compound 4: only a limit was reported; the forecaster's own chance of this, stated with the estimate: 15%; the middle value is on the limit's open side.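

In this assay compound 4 gives only a limit (< 10000 nM). Among the compounds shown here, no step linking compound 4 to compound 1, compound 2 or compound 3 can be read, because the comparison rests on a limit: the limit of < 10000 nM in this assay, at which 3 of the 4 values shown sit. From the compounds shown here alone, whether naphthalen-2-yl in place of phenyl on a carbonyl carbon strengthens or weakens inhibition stays open, as does any ordering of compound 1, compound 2 and compound 4.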